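Back to the acid: what compound 4 should show

This account rests on a few compounds, and the source may have more. Where it says the series, first, only, none or still open, it means among the compounds named here.

Compound 1 `COc1ccc(/C=C\c2cc(OC)c(OC)c(OC)c2)cc1OCc1ccc(CN2CCCCC2C(=O)O)cc1`: 14200 nM
Compound 2 `COc1ccc(/C=C\c2cc(OC)c(OC)c(OC)c2)cc1OCc1ccc(CN2CCCCC2C(=O)NCCN)cc1`: 7300 nM
Compound 3 `COc1ccc(/C=C\c2cc(OC)c(OC)c(OC)c2)cc1OCc1ccc(CNCCN(C)C)cc1`: 9400 nM

All three were tested in a functional assay on HeLa cells (Homo sapiens) for antiproliferative activity, read by CCK-8 assay, with a stated time of 48 h; a lower number here means a stronger inhibitor, a higher number a weaker inhibitor. Compound 2 gives the lowest number of the three, but its neighbours sit close: compound 3 shows a 1.3-fold higher number from compound 2 to compound 3 (0.11 log units; within the scatter) and compound 1 shows a 1.9-fold lower number from compound 1 to compound 2 (0.29 log units; within the scatter), so none of the three can be set apart from the others. The third step, a 1.5-fold lower number from compound 1 to compound 3 (0.18 log units; within the scatter), is likewise within the scatter.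

Compound 4 `COc1ccc(/C=C\c2cc(OC)c(OC)c(OC)c2)cc1OCc1ccc(CN2CCCC[C@@H]2C(=O)O)cc1` differs from compound 2 by 2-carboxypiperidin-1-yl in place of 2-((2-aminoethyl)carbamoyl)piperidin-1-yl on a saturated chain carbon bound to an aromatic carbon. The entering group is the same one compound 1 carries, so the most direct guide is the step from compound 1 to compound 2, read backwards, together with the fact that every change seen so far stayed within the scatter. The expected step is therefore small: the number for compound 4 is expected to rise slightly from compound 2, a 1.8-fold higher number from compound 2 to compound 4 (0.25 log units; within the scatter), landing close to compound 1.

For compound 4 in this assay the estimate is 13000 nM, with a range of 6000 nM to 28000 nM.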

Compound 4, half-maximal inhibitory concentration: > 10000 nM
Compound 4 was reported as a limit (the forecaster's own chance of this, stated with the estimate: 3%); the middle value does not contradict the limit.
By their numbers in this assay, from the lowest: compounds 2, 3 and 1 (each within the scatter of the next).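

Compound 4 is reported in this assay only as a limit, not as a number: > 10000 nM. Putting 2-carboxypiperidin-1-yl on this saturated chain carbon bound to an aromatic carbon gives an at least 1.3-fold higher number from compound 2 to compound 4 (0.13 log units; that floor lies within the scatter) and an at least 1.0-fold higher number from compound 3 to compound 4 (0.02 log units; that floor lies within the scatter), and since both floors lie within the scatter, the limit does not set compound 4 apart from either compound. Compound 4 adds the first defined stereocentre at this place, but the step between compound 1 and compound 4 cannot be read, so the series says nothing yet about the R configuration set against the undrawn one: the fact that one of compounds 1 and 4 is drawn with a defined configuration and the other without, at the place where they differ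

The compounds shown leave open how the S configuration of the 2-carboxypiperidin-1-yl group would compare with the R configuration, and where compound 4 would fall once given as a number rather than a limit. They also leave open whether a methyl ester in place of the carboxylic acid, or a longer chain on the amide nitrogen of the 2-((2-aminoethyl)carbamoyl)piperidin-1-yl group, would move the number in this assay beyond the scatter.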